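This account rests on a few compounds, and the source may have more. Where it says the series, first, only, none or still open, it means among the compounds named here.

Among the compounds with values here, in a functional assay on cells (strain Sprague-Dawley) for antagonist activity at transient receptor potential cation channel subfamily V member 1 (Rattus norvegicus), read by scintillation counting (a higher number here means a weaker inhibitor, a lower number a stronger inhibitor), compound 1 `C[Si](C)(C)c1ccc(CNC(=S)NCc2ccc(NS(C)(=O)=O)cc2)cc1` gives 150 nM, and compound 2 `CC[Si](C)(C)c1ccc(CNC(=S)NCc2ccc(NS(C)(=O)=O)cc2)cc1` gives 1200 nM, the higher of the two numbers measured so far. Within the data shown here, the single step on record, an 8.0-fold higher number from compound 1 to compound 2 (0.90 log units; beyond the scatter), lengthens the chain on the silicon atom. Compound 3 `CC[Si](CC)(CC)c1ccc(CNC(=S)NCc2ccc(NS(C)(=O)=O)cc2)cc1` takes that same idea further, through (a group of 7 heavy atoms (6 carbon, 1 silicon; no ring) in place of a group of 5 heavy atoms (4 carbon, 1 silicon; no ring), on an aromatic carbon). Because the earlier step was an 8.0-fold higher number from compound 1 to compound 2 (0.90 log units; beyond the scatter), compound 3 is expected to give a weaker result again, the estimated step being a 4.2-fold higher number from compound 2 to compound 3 (0.62 log units; beyond the scatter). In this assay compound 3 is therefore estimated at 5000 nM, within a range of 1500 nM to 20000 nM.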

Compound 3, half-maximal inhibitory concentration: 3100 nM
The estimate for compound 3 lay 1.6-fold (0.21 log units) above the measured number, and the stated range covers the measured number.
By their numbers in this assay, from the lowest: compound 1; then compound 2; then compound 3.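

In this assay, enlarging the silicon group a second time moves the number the same way again: a 2.6-fold higher number from compound 2 to compound 3 (0.41 log units; beyond the scatter), and over the whole series a 21-fold higher number from compound 1 to compound 3 (1.32 log units; beyond the scatter). Within the data shown here, the single step on record now becomes a trend across three compounds, none going against it, with the smallest silicon group, in compound 1, giving the lowest number. No measurement at hand explains this trend. Still open, going by these compounds, is whether tert-butyl, with carbon in place of silicon, would match compound 1, and whether a smaller group, such as a plain hydrogen, would give a lower number.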